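Swapping the aniline aryl group in an antiproliferative quinazoline series

This account rests on a few compounds, and the source may have more. Where it says the series, first, only, none or still open, it means among the compounds named here.

Compound 1 `COc1cc2ncnc(Nc3ccc(F)c(Cl)c3)c2cc1OCCCCC(=O)Nc1ccc(S(N)(=O)=O)cc1` stands at the high end of three numbers in a functional assay on A549 cells (Homo sapiens) for antiproliferative activity, read by MTT assay, with a stated time of 72 h (a higher number here means a weaker inhibitor, a lower number a stronger inhibitor), where compound 1 gives 15500 nM. Compound 2 `C#Cc1cccc(Nc2ncnc3cc(OC)c(OCCCCC(=O)Nc4ccc(S(N)(=O)=O)cc4)cc23)c1` gives 7720 nM and compound 3 `COc1cc2ncnc(Nc3cccc(Cl)c3F)c2cc1OCCCCC(=O)Nc1ccc(S(N)(=O)=O)cc1` gives 10500 nM; the steps of a 2.0-fold lower number from compound 1 to compound 2 (0.30 log units; within the scatter) and a 1.5-fold lower number from compound 1 to compound 3 (0.17 log units; within the scatter) are both within the scatter. Compound 4 `COc1cc2ncnc(Nc3ccc(C)cc3)c2cc1OCCCCC(=O)Nc1ccc(S(N)(=O)=O)cc1` differs from compound 1 only at the same nitrogen: 4-methylphenyl in place of 3-chloro-4-fluorophenyl on a nitrogen on an aromatic ring. The two measured swaps at this position, from compound 1 to compound 2 and from compound 1 to compound 3, moved the number little, so no step beyond the scatter is expected here. Compound 4 is therefore estimated at 17000 nM, between 7000 nM and 40000 nM, an expected step of a 1.1-fold higher number from compound 1 to compound 4 (0.04 log units; within the scatter).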

Compound 4, half-maximal inhibitory concentration: > 40000 nM
Compound 4 ended at the assay's limit; the forecaster's own chance of this, stated with the estimate: 5%; middle value at least 2.3-fold (0.37 log units) away from the limit.
By their numbers in this assay, from the lowest: compounds 2, 3 and 1 (each within the scatter of the next). At a limit, above all of these: compound 4.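

Compound 4 sits at a limit of this assay, not at a number: the limit of > 40000 nM in this assay, at which 1 of the 4 values shown sits. The steps are an at least 2.5-fold higher number from compound 1 to compound 4 (0.41 log units; beyond the scatter), an at least 3.8-fold higher number from compound 3 to compound 4 (0.58 log units; beyond the scatter) and an at least 5.1-fold higher number from compound 2 to compound 4 (0.71 log units; beyond the scatter), each beyond the scatter, whereas the swaps among compounds 1, 2 and 3 all stayed within it. So this position does respond to the aryl group, and losing chlorine and fluorine cannot alone be what matters, since compound 2 also carries neither.

Going by these compounds, it remains open whether the methyl group itself or its place on the ring drives the step. A 3-methylphenyl or plain phenyl group on the same nitrogen would separate the two.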